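The source may report more compounds than this note shows. Statements on the series, on what has been measured and on what is new or still open speak of the compounds shown alone.

Compound 2 `Cc1ccc(COc2ccc(C(=O)NC(=S)Nc3ccc(C)c(-c4nc5ccccc5[nH]4)c3)cc2)cc1` holds the only plain number shown in a functional assay on SW-620 cells (Homo sapiens) for inhibition, read by MTT assay, with a stated time of 48 h (a higher number here means a weaker inhibitor, a lower number a stronger inhibitor), where compound 2 gives 60900 nM. Compound 1 `Cc1ccc(NC(=S)NC(=O)c2ccc(OCc3cccc(Cl)c3Cl)cc2)cc1-c1nc2ccccc2[nH]1` reaches a limit of this assay, at > 100000 nM. Going by the values given here, the single measured step, an at least 1.6-fold lower number from compound 1 to compound 2 (0.21 log units; that floor lies within the scatter), is the only guide. Compound 3 `Cc1ccc(NC(=S)NC(=O)c2ccc(OCc3cccc(F)c3)cc2)cc1-c1nc2ccccc2[nH]1` differs from compound 2 in one place: 3-fluorophenyl in place of 4-methylphenyl on a saturated chain carbon bound to an oxygen on an aromatic ring. Because compound 1, which also carries halogen on that ring, sat at the limit (the limit of > 100000 nM in this assay, at which 1 of the 2 values shown sits), a modestly higher number is expected from the change, estimated as a 1.4-fold higher number from compound 2 to compound 3 (0.14 log units; within the scatter). For compound 3 the expected value is 85000 nM, within a range of 30000 nM to 250000 nM.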

Compound 3, half-maximal inhibitory concentration: > 100000 nM
Compound 3: a limit, no number (the forecaster's own chance of this, stated with the estimate: 35%); middle value at least 1.1-fold (0.07 log units) away from the limit.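

Compound 3 reaches a limit of this assay, not a number, so 3-fluorophenyl, like 2,3-dichlorophenyl, gives no readable value on this saturated chain carbon. Putting 3-fluorophenyl in place of 4-methylphenyl gives an at least 1.6-fold higher number from compound 2 to compound 3 (0.21 log units; that floor lies within the scatter), so even this step does not establish a real gap between the two groups. The step between compound 1 and compound 3 cannot be read, and the values shown gather at the top of the range: the limit of > 100000 nM in this assay, at which 2 of the 3 values shown sit.

On these data alone, whether an unsubstituted phenyl or a 4-aminophenyl in this place would give a plain number stays open.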